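A chlorothiophene in place of a three-heteroatom ring

The source may hold more compounds than are shown below. What is called first, only, known or untested is meant among the compounds shown, and "the series" means these compounds.

Compound 1 `Cn1nc2c(=O)n(CC3(O)CCN(Cc4ccc(-c5n[nH]c(=O)o5)cc4Cl)CC3)cnc2c1-c1ccc(CN)cc1`: 171 nM
Compound 2 `Cn1nc2c(=O)n(CC3(O)CCN(Cc4ccc(-c5ccco5)cc4Cl)CC3)cnc2c1-c1ccc(C(N)=O)cc1`: 80.8 nM
Compound 3 `Cn1nc2c(=O)n(CC3(O)CCN(Cc4ccc(-c5ccco5)cc4Cl)CC3)cnc2c1-c1ccc(C(=N)N)cc1`: 87.5 nM

All three were tested in an assay on isolated protein for inhibition of ubiquitin carboxyl-terminal hydrolase 7 (Homo sapiens), with stated times of 30 min and 2 h; a lower number here means a stronger inhibitor, a higher number a weaker inhibitor. Compound 1 gives the highest of the three numbers; compound 3 sits within the scatter of it, while compound 2 lies beyond the scatter below it. Compound 4 `Cn1nc2c(=O)n(CC3(O)CCN(Cc4ccc(-c5ccsc5Cl)cc4Cl)CC3)cnc2c1-c1ccc(CN)cc1` has not yet been measured. It differs from compound 1 in one place: a group of 6 heavy atoms (4 carbon, 1 sulfur, 1 chlorine; one five-membered aromatic ring with 1 hetero atom) in place of a group of 6 heavy atoms (2 carbon, 2 nitrogen, 2 oxygen; one five-membered aromatic ring with 3 hetero atoms), on an aromatic carbon. For the measured compounds named here, the only single step measured, a 1.1-fold higher number from compound 2 to compound 3 (0.03 log units; within the scatter), concerns another part of the shared core and says nothing about this ring exchange. Compounds 2 and 3 carry a different five-membered ring with one hetero atom in place of the ring that leaves, but they also differ from compound 1 elsewhere, so no clean comparison exists. On that loose footing, compound 4 is expected to give 100 nM, within a range from 40 nM to 250 nM. That estimate means a step of a 1.7-fold lower number from compound 1 to compound 4 (0.23 log units; within the scatter), expected as a modest move toward a lower number.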

Compound 4, half-maximal inhibitory concentration: 453 nM
Compound 4: middle estimate off by 4.5-fold (0.66 log units), on the low side, and the stated range ends below it.
By their numbers in this assay, from the lowest: compounds 2, 3 and 1 (each within the scatter of the next, the first and the last beyond it); then compound 4.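

Replacing the three-heteroatom ring of compound 1 with 2-chlorothiophen-3-yl, on the aromatic carbon para to a large group, gives a step beyond the scatter (a 2.6-fold higher number from compound 1 to compound 4 (0.42 log units; beyond the scatter)). This shows that in this assay the number responds to which five-membered ring sits at this place, with the shared core unchanged. Nothing measured here explains the rise.

As far as these compounds go, how much of the step belongs to the chlorine on the thiophene remains open, and a plain thiophen-3-yl group would separate it from the ring. Whether a carboxylic acid or an amine at this place would give a lower number is also unknown.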